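Shifting a Fluorine on the Carbonyl-Bound Ring

The source may report more compounds than this note shows. Statements on the series, on what has been measured and on what is new or still open speak of the compounds shown alone.

Of the compounds shown here, three built on one shared core have been measured in an assay on membranes from Cortex for displacement of a labelled ligand from Sigma non-opioid intracellular receptor 1 (Cavia porcellus), read by scintillation counting, with a stated time of 120 min; a lower number here means a stronger inhibitor, a higher number a weaker inhibitor. Compound 2 `O=C(c1ccc(F)cc1)N1CCC(NCCSC(c2ccc(F)cc2)c2ccc(F)cc2)CC1` gives 32.1 nM, the lowest number of the three. Compound 1 `[O-][S+](CCNC1CCN(CC(O)Cc2ccccc2)CC1)C(c1ccc(F)cc1)c1ccc(F)cc1` gives 351 nM, and compound 3 `O=C(c1ccc(F)cc1)N1CCC(NCC[S+]([O-])C(c2ccc(F)cc2)c2ccc(F)cc2)CC1` gives 1440 nM, both clearly higher than compound 2. Going by the values given here, the only step between two measured compounds that differ in a single place, a 4.1-fold higher number from compound 1 to compound 3 (0.61 log units; beyond the scatter), exchanges the group on the ring nitrogen, and so it says nothing about where a fluorine sits on an aromatic ring.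

Compound 4 `O=C(c1ccccc1F)N1CCC(NCCSC(c2ccc(F)cc2)c2ccc(F)cc2)CC1` differs from compound 2 by 2-fluorophenyl in place of 4-fluorophenyl on a carbonyl carbon. Among the compounds with values here, no measured pair tests this kind of exchange, so the expectation rests only on the fact that the same atoms are kept and merely rejoined. Compound 4 is therefore expected to land close to compound 2, with a step of a 1.2-fold higher number from compound 2 to compound 4 (0.10 log units; within the scatter) that is expected to stay within the scatter rather than move clearly in either direction. The estimate for compound 4 in this assay is 40 nM, within a range from 15 nM to 110 nM.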

Compound 4, inhibition constant: 3.57 nM
For compound 4 the middle estimate is 11-fold (1.05 log units) above the measured one; measured number below the stated range.
By their numbers in this assay, from the lowest: compound 4; then compound 2; then compound 1; then compound 3.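

In this assay, 2-fluorophenyl in place of 4-fluorophenyl on a carbonyl carbon gives a 9.0-fold lower number from compound 2 to compound 4 (0.95 log units; beyond the scatter), so where the fluorine sits on this ring matters, even though both groups contain the same atoms. The earlier step exchanged the entire group on the ring nitrogen, whereas this one shows that rejoining the same atoms is enough to move the number beyond the scatter. No measurement shown here explains the size or direction of this step.

The compounds shown leave open whether a chlorine atom or a methoxy group in place of this fluorine would give a similarly low number. They also leave open whether the same exchange would produce a step of similar size in compound 3, which carries the same (4-fluorophenyl)carbonyl group.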